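This account rests on a few compounds, and the source may have more. Where it says the series, first, only, none or still open, it means among the compounds named here.

Values from a functional assay on HUVEC cells (Homo sapiens) for inhibition, with a stated time of 4 days (on this read-out higher numbers stand for weaker inhibition and lower numbers for stronger inhibition), follow
Compound 1 (`COc1ccc(C(N)=O)cc1/C=C/c1ccc(Cl)cc1`) gives 87 nM
Compound 2 (`COc1ccc(C(N)=O)cc1/C=C/c1ccc(C(C)(C)C)cc1`) gives 370 nM
Compound 3 (`COc1ccc(C(N)=O)cc1/C=C/c1ccc(F)cc1`) gives 2100 nM

Compound 1 has the lowest number of the three, which makes it the strongest inhibitor so far. Compound 4 (`COc1ccc(C(=O)N(C)C)cc1/C=C/c1ccc(Cl)cc1`) keeps the core of compound 1 and alters the amide. The change is dimethylamino in place of amino on a carbonyl carbon and, in words, dimethylamino in place of amino on a carbonyl carbon. Among the measured compounds shown here, no measured step touches this place. The three known steps are a 4.3-fold higher number from compound 1 to compound 2 (0.63 log units; beyond the scatter) and a 24-fold higher number from compound 1 to compound 3 (1.38 log units; beyond the scatter) and a 5.7-fold higher number from compound 2 to compound 3 (0.75 log units; beyond the scatter) and all of them swap the group on an aromatic carbon. For the measured compounds named here, they show only that one small change can shift the number by a modest to large amount in this set. They give no direct guide to the amide. Compound 1 already sits at the low end with 87 nM so a higher number seems the likelier outcome, with real uncertainty. The expected change is a 5.2-fold higher number from compound 1 to compound 4 (0.71 log units; beyond the scatter) as a rough estimate. The expected value for compound 4 is 450 nM and the estimated range runs from 70 nM to 3000 nM on this scale.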

Compound 4, half-maximal inhibitory concentration: 2500 nM
Compound 4: middle estimate off by 5.6-fold (0.74 log units), on the low side; measured number inside the range.
By their numbers in this assay, from the lowest: compound 1; then compound 2; then compounds 3 and 4 (each within the scatter of the next).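

The amide is not a passive part of this series: in this assay, replacing amino with dimethylamino on the carbonyl carbon gives a 29-fold higher number from compound 1 to compound 4 (1.46 log units; beyond the scatter). Among the compounds shown here, the earlier steps changed only the group on an aromatic carbon, so this is the first sign that the carbamoyl end of the molecule also matters to the read-out. The change removes the hydrogen-bond donor counted on amino and adds two carbons at once, and no measurement shown here gives a cause for the step or separates those two differences.

The compounds shown leave open whether methylamino, with its single methyl, would behave more like amino or more like dimethylamino. They also leave open how a carboxylic acid in place of the amide would compare, and whether the same swap would have a similar effect with tert-butyl or fluoro in place of chloro.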